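This account rests on a few compounds, and the source may have more. Where it says the series, first, only, none or still open, it means among the compounds named here.

Three compounds built around the same kind of core, each carrying a carboxylic acid on one end and a methyl-bearing benzyl group on the other, were tested in a functional assay on HeLa cells (Homo sapiens) for cytotoxicity, read by MTT assay, with a stated time of 48 h; a lower number here means a stronger inhibitor, a higher number a weaker inhibitor. Compound 1, `Cc1ccc(Cn2c(/C=C3\SC(=S)N(CC(=O)O)C3=O)nc3cc(F)ccc32)cc1`, gives 2380 nM. Compound 2, `Cc1ccc(Cn2c(/C=C3\SC(=S)N(CC(=O)O)C3=O)nc3ccc(F)cc32)cc1`, gives 3920 nM. The cores of compound 1 and compound 2 are made of the same atoms joined differently, and the difference between the two cores is not broken down here. Compound 3, `COc1ccc2c(c1)nc(/C=C1\SC(=S)N(CC(=O)O)C1=O)n2Cc1ccc(C)cc1`, gives 1820 nM. Compound 3 arises from compound 1 by a single change, (methoxy in place of fluoro on an aromatic carbon), and that change produced a 1.3-fold lower number from compound 1 to compound 3 (0.12 log units; within the scatter). The numbers for compound 1 and compound 2 lie within the scatter of each other, so no order between them can be read. Compound 3 gives a lower number than compound 2, and that gap is beyond the scatter.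

Compound 4, `COc1ccc2nc(/C=C3\SC(=S)N(CC(=O)O)C3=O)n(Cc3ccc(C)cc3)c2c1`, has not yet been measured. It arises from compound 2 by methoxy in place of fluoro on an aromatic carbon. For the measured compounds named here, this is the same change, at the same kind of place, as the one that turned compound 1 into compound 3, and that single earlier step is the only guide to what it may do here. Because that step gave a 1.3-fold lower number from compound 1 to compound 3 (0.12 log units; within the scatter), the step from compound 2 to compound 4 in this assay is expected to be similar, namely a 1.3-fold lower number from compound 2 to compound 4 (0.12 log units; within the scatter). Compound 4 is accordingly estimated at 3000 nM, expected to fall between 1500 nM and 6000 nM.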

Compound 4, half-maximal inhibitory concentration: 6440 nM
Beside the measured number, compound 4's estimate is 2.1-fold (0.33 log units) below it; measured number above the stated range.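

In this assay, putting methoxy in place of fluoro on the core of compound 2 gave a 1.6-fold higher number from compound 2 to compound 4 (0.22 log units; within the scatter), and the same replacement on the core of compound 1 gave a 1.3-fold lower number from compound 1 to compound 3 (0.12 log units; within the scatter). Each step is small enough to be ordinary variation between repeated measurements, and setting the two side by side reveals no real difference between them: the same change on two cores in this assay, a 1.3-fold lower number (0.12 log units; within the scatter) from compound 1 to compound 3 and a 1.6-fold higher number (0.22 log units; within the scatter) from compound 2 to compound 4, 2.1-fold (0.33 log units) apart, within the scatter of two such steps. This shows that the two cores cannot be told apart in how they respond to this replacement, but it does not prove that the replacement acts alike on both, since no direction can be read from either step and a single pair of steps is a thin basis for any rule about carrying the change from one core to another.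

The compounds shown carry only fluoro or methoxy on this aromatic carbon, so what an amine, a nitrile or a longer chain would do there remains open. All four also share the carboxylic acid and the methyl-bearing benzyl group, which leaves open whether the replacement would behave the same way with an ester in place of that acid.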